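The source may report more compounds than this note shows. Statements on the series, on what has been measured and on what is new or still open speak of the compounds shown alone.

The measured compounds:
Compound 1, `Cc1cc(-c2ccccc2)c(S(C)(=O)=O)cc1C(=O)N=C(N)N`, gives 19 nM in a functional assay for inhibition of sodium/hydrogen exchanger (Oryctolagus cuniculus); a higher number here means a weaker inhibitor, a lower number a stronger inhibitor.
Compound 2, `CS(=O)(=O)c1cc(C(=O)N=C(N)N)ccc1-n1cccn1`, gives 160 nM in this assay.
Compound 3, `Cc1cc(-n2cccn2)c(S(C)(=O)=O)cc1C(=O)N=C(N)N`, gives 25 nM in this assay.

Compound 2 has the highest number of the three in this assay. Compound 3 is nearest to it, with a 6.4-fold lower number from compound 2 to compound 3 (0.81 log units; beyond the scatter), and compound 1 lies furthest below it. Compound 4, `CS(=O)(=O)c1cc(C(=O)N=C(N)N)ccc1Cl`, has not yet been measured. It differs from compound 2 by chloro in place of 1H-pyrazol-1-yl on an aromatic carbon. Among the compounds with values here, no measured step exchanges a ring substituent at that carbon for a single atom. The step of a 1.3-fold higher number from compound 1 to compound 3 (0.12 log units; within the scatter) shows that one ring in place of another at that carbon left the number essentially unchanged, while a 6.4-fold lower number from compound 2 to compound 3 (0.81 log units; beyond the scatter) concerns a different position. The data therefore give no firm direction for the present change. The expectation is that compound 4 stays close to compound 2, perhaps somewhat lower, with wide uncertainty. For compound 4 the estimate is 100 nM, with a range from 30 nM to 400 nM. This estimate corresponds to an expected step of a 1.6-fold lower number from compound 2 to compound 4 (0.20 log units; within the scatter).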

Compound 4, half-maximal inhibitory concentration: 380 nM
Compound 4: the middle estimate sits 3.8-fold (0.58 log units) below what was measured; the range from low to high includes it.
By their numbers in this assay, from the lowest: compounds 1 and 3 (each within the scatter of the next); then compound 2; then compound 4.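

Within the data shown here, at this carbon, ortho to a methylsulfonyl group and para to a group of 6 heavy atoms, compound 4 gives the first exchange of a ring for a single atom, and in this assay chloro in place of 1H-pyrazol-1-yl gives a 2.4-fold higher number from compound 2 to compound 4 (0.38 log units; beyond the scatter). Replacing the ring with chloro therefore moves the number modestly but beyond the scatter, whereas the earlier ring-for-ring exchange at this carbon gave only a 1.3-fold higher number from compound 1 to compound 3 (0.12 log units; within the scatter). Nothing shown here accounts for the direction of this step.

The compounds leave open whether chloro in place of 1H-pyrazol-1-yl would move the number the same way with the methyl group of compound 3 present. They also do not tell how an amine, a methoxy group or a bare hydrogen at this carbon would compare.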